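The compounds below may be only part of what the source reports. "The series", "measured", "known", "first", "only" and "open" are said of these compounds alone.

Three compounds have been measured in a functional assay on HCT-116 cells (Homo sapiens) for antiproliferative activity, read by MTT assay, with a stated time of 24 h; on this read-out higher numbers stand for weaker inhibition and lower numbers for stronger inhibition:

- Compound 1 `COc1cccc(/C=C/C(=O)c2ccc(OC)c3c2OC(C)(C)C=C3)c1`: > 10000 nM, a limit of the assay
- Compound 2 `COc1ccc(C(=O)/C=C/c2ccc3ccccc3c2)c2c1C=CC(C)(C)O2`: 5820 nM
- Compound 3 `COc1ccc(C(=O)/C=C/c2ccc(-c3ccccc3)cc2)c2c1C=CC(C)(C)O2`: > 10000 nM, a limit of the assay

Compound 3 therefore has no exact number, only the limit > 10000 nM. The picture so far is defined by the limit of > 10000 nM in this assay, at which 2 of the 3 values shown sit. Compound 2 is the only one of the three with a number, 5820 nM.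

Compound 4 `COc1ccc(C(=O)/C=C/c2ccccc2)c2c1C=CC(C)(C)O2` has not yet been measured in this assay. It carries hydrogen in place of phenyl on an aromatic carbon, para to a large group: hydrogen in place of phenyl on an aromatic carbon. Among the compounds with values here, no measured pair isolates this change, so any forecast is uncertain. A small shift towards stronger inhibition, or none beyond the scatter, is the expectation, resting on compound 2 at 5820 nM as the only numerical anchor. The expected change is an at least 1.1-fold lower number from compound 3 to compound 4 (0.04 log units; that floor lies within the scatter). For compound 4 the estimated value is 9000 nM, with an expected range of 3500 nM to 20000 nM.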

Compound 4, half-maximal inhibitory concentration: > 10000 nM
Compound 4: no number, only a limit; the forecaster's own chance of this, stated with the estimate: 55%; middle value at least 1.1-fold (0.04 log units) from the limit.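

Compound 4 gives the limit > 10000 nM in this assay and so adds no number, which leaves the steps to it from compound 3 and compound 1 unreadable: the limit of > 10000 nM in this assay, at which 3 of the 4 values shown sit.

On these data alone, what hydrogen in place of phenyl or methoxy on an aromatic carbon does to inhibition stays open.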